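From Methyl to Methoxy on the Aryl Group

A few compounds are considered here, and "the series" means these few. Any claim that something is new, unique, unknown or untested is made for them only; others in the source may bear on it.

Three compounds share one core and differ only on an amide-type nitrogen. In a functional assay on the whole organism for inhibition, with Lemna aequinoctialis as the target, tested at 10 ug/mL (on this read-out higher numbers stand for more inhibition of growth at the one concentration tested and lower numbers for less inhibition of growth), compound 1 `CCCCCCNC(=S)N/N=C1\C(=O)Nc2ccc([N+](=O)[O-])cc21` gives 25%. Compound 2 `Cc1cccc(NC(=S)N/N=C2\C(=O)Nc3ccc([N+](=O)[O-])cc32)c1` gives 10%, and compound 3 `Cc1ccc(NC(=S)N/N=C2\C(=O)Nc3ccc([N+](=O)[O-])cc32)cc1` gives 15%, which places compound 3 second highest of the three, within the scatter of both other numbers. The measured steps are a number 15 percentage points lower from compound 1 to compound 2 (beyond the scatter), a number 10 percentage points lower from compound 1 to compound 3 (within the scatter) and a number 5 percentage points higher from compound 2 to compound 3 (within the scatter). Compound 4 `COc1ccc(NC(=S)N/N=C2\C(=O)Nc3ccc([N+](=O)[O-])cc32)cc1` carries methoxy in place of methyl on an aromatic carbon. Going by the values given here, no measured step exchanges methyl for methoxy, and the one exchange between aryl groups already measured stayed within the scatter. Compound 4 is therefore expected to show no change at the digits printed from compound 3 to compound 4 (within the scatter), nothing beyond the scatter. Compound 4 is estimated at 15%, with a range from 5% to 30%.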

Compound 4, percent growth inhibition at one concentration: 10%
Beside the measured number, compound 4's estimate is 5 percentage points above it; measured number inside the range.
By their numbers in this assay, from the lowest: compounds 2, 4, 3 and 1 (each within the scatter of the next, the first and the last beyond it).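

Methoxy in place of methyl on this aromatic carbon gives a number 5 percentage points lower from compound 3 to compound 4 (within the scatter) in this assay and so adds a hydrogen-bond acceptor with no change beyond the scatter. Set against the 3-methylphenyl group, the 4-methoxyphenyl group gives no change at the digits printed from compound 2 to compound 4 (within the scatter) as well. Against hexyl it gives a number 15 percentage points lower from compound 1 to compound 4 (beyond the scatter) and thereby joins compound 2 in lying beyond the scatter of compound 1, while compound 3 goes against that pattern. No evidence bears on the cause of these numbers. On these data alone, whether an amine or a carboxylic acid on this aromatic carbon, or a chain longer than hexyl on the amide-type nitrogen, would move the number beyond the scatter stays open.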